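Pyridin-3-yl for 3-fluorophenyl: compound 3 to compound 4

The source may hold more compounds than are shown below. What is called first, only, known or untested is meant among the compounds shown, and "the series" means these compounds.

In a functional assay on A549 cells (Homo sapiens) for antiproliferative activity, read by sulforhodamine B assay, with a stated time of 48 h (a higher number here means a weaker inhibitor, a lower number a stronger inhibitor), compound 3 (`COc1ccc(/C=C/C(=O)c2ccccc2-c2cccc(F)c2)cc1`) gives 280 nM. That value lies within the scatter of compound 2 (`COc1ccc(/C=C/C(=O)c2ccccc2-c2ccc(F)cc2)cc1`), which gives 140 nM. For the measured compounds named here, compound 1 (`COc1ccc(-c2ccccc2C(=O)/C=C/c2ccc(Br)cc2)cc1OC`) gives 6800 nM, well beyond the scatter of compound 3, but it differs from compound 3 in more than one place and offers no clean step.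

The next structure is compound 4 (`COc1ccc(/C=C/C(=O)c2ccccc2-c2cccnc2)cc1`), with pyridin-3-yl in place of 3-fluorophenyl on an aromatic carbon. Going by the values given here, the only measured single-place step is a 2.0-fold higher number from compound 2 to compound 3 (0.30 log units; within the scatter), with 3-fluorophenyl in place of 4-fluorophenyl, and it lies within the scatter. Among the compounds with values here, it shows that this assay changed little when the fluorine-bearing group was altered, but no measured step puts a hetero atom into this aromatic ring. The data therefore give no direct size for the change.

A small shift toward a higher number is expected, and the expected step is a 1.8-fold higher number from compound 3 to compound 4 (0.25 log units; within the scatter), which stays within the scatter. The range is kept wide on the high side, given the untested nature of the change. For compound 4 the estimated value is 500 nM, with an expected range from 150 nM to 2500 nM.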

Compound 4, half-maximal inhibitory concentration: 580 nM
Estimate against measurement, compound 4: 1.2-fold (0.06 log units) below; measured number inside the range.
By their numbers in this assay, from the lowest: compounds 2 and 3 (each within the scatter of the next); then compound 4; then compound 1.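

In this assay this position, on an aromatic carbon ortho to a large group, now shows a weaker inhibitor with a step beyond the scatter: a 2.1-fold higher number from compound 3 to compound 4 (0.32 log units; beyond the scatter) and, measured against the other fluorine-bearing compound, a 4.1-fold higher number from compound 2 to compound 4 (0.62 log units; beyond the scatter) with pyridin-3-yl in place of 4-fluorophenyl. For the compounds shown here, the earlier step here, a 2.0-fold higher number from compound 2 to compound 3 (0.30 log units; within the scatter), stayed within the scatter, so the first change at this carbon to leave the scatter is the one that replaces a ring of carbon only with a ring holding a hetero atom, though both new steps remain modest in size. No measurement in hand bears on the reason for this loss, and the step is recorded here only as a size.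

Still open, as far as these compounds go, is which part of the swap carries the step, the loss of the fluorine or the entry of the ring nitrogen with its hydrogen-bond acceptor, and an unsubstituted phenyl at this carbon would separate the two. Also open, from the compounds shown here alone, is how pyridin-2-yl, pyridin-4-yl or a phenyl bearing an amine or a carboxylic acid would read at the same place.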